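This account rests on a few compounds, and the source may have more. Where it says the series, first, only, none or still open, it means among the compounds named here.

Measured compounds:
compound 1, `COc1ccc(-c2cc(/C=C/C(=O)c3ccc(N)cc3)[nH]n2)cc1`: 63%
compound 2, `COc1cc(-c2cc(/C=C/C(=O)c3ccc(N)cc3)[nH]n2)cc(OC)c1OC`: 79%
compound 3, `COc1ccc(C(=O)/C=C/c2cc(-c3cc(OC)c(OC)c(OC)c3)n[nH]2)cc1`: 89%

These values come from a functional assay on OVCAR-3 cells (Homo sapiens) for cytotoxicity, read by sulforhodamine B assay, with a stated time of 48 h, tested at 1 uM; on this read-out higher numbers stand for a weaker effect at the one concentration tested and lower numbers for a stronger effect. Among the three numbers compound 2 stands second highest; its nearest neighbour is compound 3, with a number 10 percentage points higher from compound 2 to compound 3 (within the scatter), while compound 1 lies furthest from it, beyond the scatter. Compound 4, `COc1ccc(-c2cc(/C=C/C(=O)c3ccc(N)cc3)[nH]n2)cc1OC`, is made from compound 2 by one change: hydrogen in place of methoxy on an aromatic carbon. Among the measured compounds shown here, no measured step shows this same change. For the measured compounds named here, the only guide is that compound 1 carries one methoxy fewer still than compound 4 on that ring, and compound 1 gives 63% against compound 2 at 79%. Compound 4 is therefore expected to land between them, with a number 9 percentage points lower from compound 2 to compound 4 (within the scatter) estimated. The estimate for compound 4 is 70%, ranging from 58% to 84%.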

Compound 4, a percentage reported as activity, at one concentration (the size of the read-out at that concentration, not a potency): 92%
For compound 4 the middle estimate is 22 percentage points below the measured one, and the stated range ends below it.
By their numbers in this assay, from the lowest: compound 1; then compounds 2, 3 and 4 (each within the scatter of the next, the first and the last beyond it).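

In this assay, methoxy on this ring does not push the read-out one way: hydrogen in place of methoxy gives a number 13 percentage points higher from compound 2 to compound 4 (beyond the scatter), while methoxy in place of hydrogen gives a number 29 percentage points higher from compound 1 to compound 4 (beyond the scatter). Both single changes therefore lead to a weaker effect at compound 4, so the outcome depends on which methoxy groups are present, not simply on whether one is added or removed. Nothing available explains this reversal.

On these data alone, whether a hydroxy group or a fluorine atom at this position would behave like methoxy or like hydrogen stays open. So does whether the same step would hold with methoxy in place of the amino group of compound 4.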